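This account rests on a few compounds, and the source may have more. Where it says the series, first, only, none or still open, it means among the compounds named here.

Series notes: in a functional assay on A549 cells (Homo sapiens) for inhibition, read by MTT assay, with a stated time of 24 h (a higher number here means a weaker inhibitor, a lower number a stronger inhibitor), compound 1 (`CC1(C)[C@H]2CC[C@]1(C)N(Cc1cn(-c3ccccc3Br)nn1)C(=O)C2`) gives 130 nM, compound 2 (`CC1(C)[C@H]2CC[C@]1(C)N(Cc1cn(-c3ccccc3C#N)nn1)C(=O)C2`) gives 100 nM and compound 3 (`CC1(C)[C@H]2CC[C@]1(C)N(Cc1cn(-c3ccccc3Cl)nn1)C(=O)C2`) gives 70 nM. Compound 3 has the lowest of the three numbers, but it is not separated from the other two: the steps of a 1.9-fold lower number from compound 1 to compound 3 (0.27 log units; within the scatter) and a 1.4-fold lower number from compound 2 to compound 3 (0.15 log units; within the scatter) both lie within the scatter, as does a 1.3-fold lower number from compound 1 to compound 2 (0.11 log units; within the scatter).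

Next comes compound 4 (`CC1(C)[C@H]2CC[C@]1(C)N(Cc1cn(-c3ccc(O)cc3)nn1)C(=O)C2`), where 4-hydroxyphenyl replaces 2-chlorophenyl on an aromatic nitrogen of the five-membered aromatic ring with 3 nitrogen: 4-hydroxyphenyl in place of 2-chlorophenyl on an aromatic nitrogen.

For the measured compounds named here, the three measured steps are the only guide, and they bear on this change only in part. Each swaps one group on an aromatic carbon, among bromo, cyano and chloro. None introduces a hydroxy group, and none moves the substituent on the phenyl group. The flat response seen in a 1.9-fold lower number from compound 1 to compound 3 (0.27 log units; within the scatter) therefore gives weak support for expecting a small step, and the data do not fix its direction. Going by the values given here, a modest move to a higher number is assumed, given that compound 3 has the lowest value so far, at 70 nM.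

The expected change is a 1.9-fold higher number from compound 3 to compound 4 (0.27 log units; within the scatter), which may not exceed the scatter. In this assay the estimate for compound 4 is 130 nM, with an expected range of 40 nM to 450 nM.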

Compound 4, half-maximal inhibitory concentration: 140 nM
Beside the measured number, compound 4's estimate is 1.1-fold (0.03 log units) below it, and the stated range covers the measured number.
By their numbers in this assay, from the lowest: compounds 3, 2, 1 and 4 (each within the scatter of the next).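

In this assay, replacing the whole substituted phenyl group on the aromatic nitrogen also gives only small steps: a 2.0-fold higher number from compound 3 to compound 4 (0.30 log units; within the scatter), a 1.4-fold higher number from compound 2 to compound 4 (0.15 log units; within the scatter) and a 1.1-fold higher number from compound 1 to compound 4 (0.03 log units; within the scatter) are the readings for this change. For the compounds shown here, the earlier steps swapped only one group on an aromatic carbon, whereas this change introduces a hydroxy group, moves the substituent on the phenyl group and, relative to 2-chlorophenyl, adds a hydrogen-bond donor and a hydrogen-bond acceptor, and even so no step leaves the scatter. No supporting data bear on why the numbers stay this close.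

The hydroxy group and the shifted substituent change together here, so the contribution of each cannot be separated from these compounds. Also open, as far as these compounds go, is whether an amine or a carboxylic acid on the phenyl group, or a longer chain in place of that group on the aromatic nitrogen, would give a step beyond the scatter.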